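Chloro in Place of Methyl: A Single Measured Anchor

The source may report more compounds than this note shows. Statements on the series, on what has been measured and on what is new or still open speak of the compounds shown alone.

The series is a small one. Going by the values given here, compound 1 `Cc1ccc(/C=N/NC(=S)N2CCNCC2)cc1` is the only member with a numeric result: in a functional assay on HL-60 cells (Homo sapiens) for antiproliferative activity, with a stated time of 48 h (a lower number here means a stronger inhibitor, a higher number a weaker inhibitor), compound 1 gives 70000 nM. Compound 2 `C/C(=N/NC(=S)N1CCNCC1)c1ccccc1` has no number in this assay; for compound 2 the entry reads "not determined" (no result reported). The same holds for compound 3 `S=C(NN=C(c1ccccc1)c1ccccc1)N1CCNCC1`, for which this assay records "not determined" (no result reported). Among the compounds with values here, compound 1 therefore stands alone as the single measured point, with nothing to rank it against, and no step between two measured compounds exists to show what a change on the aromatic ring does to the half-maximal inhibitory concentration.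

Compound 4 `S=C(N/N=C/c1ccc(Cl)cc1)N1CCNCC1` differs from compound 1 in one place: chloro in place of methyl on an aromatic carbon, para to a large group. Within the data shown here, with no measured step available, the expectation for this assay rests on the single value of compound 1 and on the smallness of the change. The step from compound 1 to compound 4 is expected to be modest, estimated as a 1.8-fold lower number from compound 1 to compound 4 (0.24 log units; within the scatter), toward a somewhat stronger inhibitor. Compound 4 is thus expected to give an estimated 40000 nM in this assay, with a range from 10000 nM to 150000 nM.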

Compound 4, half-maximal inhibitory concentration: 69000 nM
For compound 4 the middle estimate is 1.7-fold (0.24 log units) below the measured one; the range from low to high includes it.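

In this assay, putting chloro in place of methyl on an aromatic carbon, para to a large group, gives a 1.0-fold lower number from compound 1 to compound 4 (0.01 log units; within the scatter) and so separates compound 1 from compound 4 by nothing that can be told from the usual scatter of repeated measurements. Going by these compounds alone, until this result the series held a single number with no partner, so nothing could be said about this position; now one exchange of one heavy atom for another has been read there, and the read-out does not distinguish the two groups. This holds for methyl and chloro at this one place on the aromatic ring of the shared core and for this one cell-based read-out, and it says nothing yet about any other place on the molecule.

Within the data shown here, compound 2 and compound 3 still carry no number, so no step to either can be read, and it stays open whether a larger or differently built group at this position, such as an amine, a carboxylic acid or a longer chain, would move the half-maximal inhibitory concentration at all. Nothing in hand bears on why methyl and chloro read alike here.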